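The source may report more compounds than this note shows. Statements on the series, on what has been measured and on what is new or still open speak of the compounds shown alone.

Compound 1 `Cc1cc(Nc2cc(Cl)cc(S(F)(F)(F)(F)F)c2)nc(N)n1` and compound 2 `Cc1cc(Nc2cc(Cl)cc(-c3cncs3)c2)nc(N)n1` share one core and differ only in the group carried on an aromatic carbon of the six-membered carbon ring. In an assay on cells for inhibition of S-adenosylmethionine decarboxylase proenzyme (Homo sapiens), read by mass spectrometry, at pH 7.2 (a lower number here means a stronger inhibitor, a higher number a weaker inhibitor), compound 1 gives > 180000 nM, which is a limit of the assay and not a number. In this assay compound 2 gives > 21000 nM, again a limit and not a number. The step that the two limits leave unreadable from compound 1 to compound 2 therefore cannot be read in size or direction, both ends resting on limits, as the limit of > 180000 nM in this assay, at which 1 of the 2 values shown sits, and the limit of > 21000 nM in this assay, at which 1 of the 2 values shown sits, show. Going by the values given here, on the numbers so far compound 2 stands only as a limit, with no measured potency.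

Compound 3 `Cc1cc(Nc2cc(Cl)cc(-c3cnn(C)c3)c2)nc(N)n1` carries 1-methyl-1H-pyrazol-4-yl in place of 1,3-thiazol-5-yl on an aromatic carbon. No measured step bears directly on this exchange; the one step shown is unreadable. Nothing in the shown values points to a gain beyond the scatter in this assay. Compound 3 is expected to show a step that the limit leaves unreadable from compound 2 to compound 3 that amounts to no readable change. For compound 3 in this assay the estimate is 50000 nM, with a range from 10000 nM to 300000 nM, most likely reported once more only as a limit.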

Compound 3, half-maximal inhibitory concentration: > 180000 nM
Compound 3: only a limit was reported (the forecaster's own chance of this, stated with the estimate: 70%); middle value at least 3.6-fold (0.55 log units) from the limit.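

In this assay compound 3 gives > 180000 nM, a limit of the assay and not a number. The steps from compound 1 and from compound 2 to compound 3 cannot be read in size or direction. The compounds shown leave open whether any group at this place on the shared core gives a readable potency in this assay.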